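The source may hold more compounds than are shown below. What is called first, only, known or untested is meant among the compounds shown, and "the series" means these compounds.

Measured compounds:
Compound 1, `Cc1ccc(C(Br)C(Br)c2ncc([N+](=O)[O-])n2C)cc1`: 11200 nM
Compound 2, `Cn1c([N+](=O)[O-])cnc1C(Br)C(Br)c1ccc(Br)cc1`: 7940 nM
Compound 3, `Cc1ccc(C(O)C(O)c2ncc([N+](=O)[O-])n2C)cc1`: a limit of the assay, > 100000 nM

In an ADME assay on HeLa cells (Homo sapiens) for cytotoxicity, read by resazurin assay, with a stated time of 2 days (on this read-out lower numbers stand for stronger inhibition and higher numbers for weaker inhibition), compound 1 gives 11200 nM. In this assay compound 2 gives 7940 nM. Compound 2 differs from compound 1 by bromo in place of methyl on an aromatic carbon
and this change made a 1.4-fold lower number from compound 1 to compound 2 (0.15 log units; within the scatter). Compound 3 reaches only a limit of this assay, > 100000 nM. The difference between the cores of compound 1 and compound 3 is not broken down here.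

Compound 4, `Cn1c([N+](=O)[O-])cnc1C(O)C(O)c1ccc(Br)cc1`, has not yet been measured in this assay. It differs from compound 3 by bromo in place of methyl on an aromatic carbon
which is the same change as the one from compound 1 to compound 2, at the same place. Since compound 3 stands at the limit of > 100000 nM in this assay, at which 1 of the 3 values shown sits, the measured step gives no more than a sign that this change left the number nearly where it was. For compound 4 the step that the limit leaves unreadable from compound 3 to compound 4 is expected, resting on the small step of a 1.4-fold lower number from compound 1 to compound 2 (0.15 log units; within the scatter) seen for the same change. Compound 4 is therefore estimated at 120000 nM, with a range from 50000 nM to 300000 nM, and most likely only a limit will again be reported.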

Compound 4, half-maximal inhibitory concentration: 91200 nM
Compound 4: middle estimate off by 1.3-fold (0.12 log units), on the high side; the measured number falls inside the stated range.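

In this assay, bromo in place of methyl on an aromatic carbon gave an at least 1.0-fold lower number from compound 3 to compound 4 (0.04 log units; that floor lies within the scatter). Set beside the earlier step, the change can be compared across the two cores only this far: the same change on two cores in this assay, a 1.4-fold lower number (0.15 log units; within the scatter) from compound 1 to compound 2 and an at least 1.0-fold lower number (0.04 log units; that floor lies within the scatter) from compound 3 to compound 4; the limit leaves it open whether they differ The value of compound 3 is a limit, so the true size of the new step stays unknown and a larger step on this core is not excluded: the limit of > 100000 nM in this assay, at which 1 of the 4 values shown sits.

The series therefore offers no proof that the change carries over from one core to the other with the same size, only that nothing measured here speaks against it. The compounds shown leave open what other groups at this place on the aromatic ring, such as chloro, methoxy or an amine, would give on either core. They also leave open what an amine or a methoxy group in place of the hydroxy groups of compound 3 would give in this assay.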